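Removing a bromo group: the same change on a second core

A few compounds are considered here, and "the series" means these few. Any claim that something is new, unique, unknown or untested is made for them only; others in the source may bear on it.

Compound 1 `COc1cc(Br)cc(/C=C/C(=O)c2ccccc2)c1O` gives 28.1% in a functional assay on MCF7 cells (Homo sapiens) for antiproliferative activity, read by sulforhodamine B assay, with a stated time of 72 h, tested at 30 uM; a lower number here means a stronger effect, a higher number a weaker effect of the compound at the concentration tested.
Compound 2 `COc1cc(Br)cc(/C=C/C(=O)c2ccc(Br)cc2)c1O` gives 48.3% in this assay.
Compound 3 `COC(=O)C1=C(N)Oc2ccc(Br)cc2C1CC(=O)c1ccc(Br)cc1` gives 34.8% in this assay.

Compound 4 `COC(=O)C1=C(N)Oc2ccc(Br)cc2C1CC(=O)c1ccccc1` has not yet been measured. The difference between the core of compound 3 and that of compound 2 is not broken down here. Within the pair already measured, the change hydrogen in place of bromo on an aromatic carbon made a step of a number 20.2 percentage points lower from compound 2 to compound 1 (beyond the scatter). Compound 4 relates to compound 3 by the same kind of change, (hydrogen in place of bromo on an aromatic carbon), with the place described in the same words. For compound 4 a step of similar direction is expected, a number 14.8 percentage points lower from compound 3 to compound 4 (beyond the scatter), which rests on the step from compound 2 to compound 1 and on the value of compound 3, 34.8%; the different core widens the uncertainty. The expected value for compound 4 in this assay is 20%, estimated between 5% and 40%.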

Compound 4, a percentage reported as activity, at one concentration (the size of the read-out at that concentration, not a potency): 41.3%
Compound 4: middle estimate off by 21.3 percentage points, on the low side; the whole stated range lies below it.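

On the second core, the change from 4-bromophenyl to phenyl gave a number 6.5 percentage points higher from compound 3 to compound 4 (within the scatter) in this assay, so compound 4 cannot be told apart from compound 3 in this read-out. The step seen on the first core therefore did not carry over to the second: the same change on two cores in this assay, a number 20.2 percentage points lower (beyond the scatter) from compound 2 to compound 1 and a number 6.5 percentage points higher (within the scatter) from compound 3 to compound 4, 26.7 percentage points apart, beyond the scatter of two such steps

This shows that, across these two pairs, the result of the change depends on the core, but it does not show which part of the core matters, or why, and two pairs say nothing about any further core. The compounds shown carry only bromo or hydrogen in this place. As far as these compounds go, how a chloro, a methoxy or an amino group there would read on either core remains open.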